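Moving a chlorine on the dichlorophenyl group

The compounds below may be only part of what the source reports. "The series", "measured", "known", "first", "only" and "open" are said of these compounds alone.

Compound 1 `Cc1cc(=O)c2c(O)cc(OCc3ccccc3Br)c([C@H]3CCN(C)C[C@H]3O)c2o1`: 45%
Compound 2 `Cc1oc2c([C@H]3CCN(C)C[C@H]3O)c(O)cc(O)c2c(=O)c1C(O)c1c(Cl)cccc1Cl`: 33%

Among the compounds with values here, in a functional assay on MCF7 cells (Homo sapiens) for inhibition, read by MTT assay, with a stated time of 48 h, tested at 10 uM (a lower number here means less inhibition of growth, a higher number more inhibition of growth at the concentration tested), compound 2 gives 33%, the lower of the two numbers so far, and compound 1 gives 45%, a gap beyond the usual scatter of repeated measurements. These two compounds differ in more than one place, so their gap cannot be tied to any single change.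

Compound 3 `Cc1oc2c([C@H]3CCN(C)C[C@H]3O)c(O)cc(O)c2c(=O)c1C(O)c1cccc(Cl)c1Cl` has not yet been measured. It matches compound 2 except for one group: 2,3-dichlorophenyl in place of 2,6-dichlorophenyl on a saturated chain carbon bound to an aromatic carbon and an oxygen on a saturated carbon. Here, 2,3-dichlorophenyl stands in place of 2,6-dichlorophenyl, with the same atoms joined differently. Within the data shown here, no measured pair shows what this exchange does, so only a small change with no firm direction is expected, and the expected step is a number 2 percentage points higher from compound 2 to compound 3 (within the scatter), within the scatter. In this assay the estimate for compound 3 is 35%, with an expected range from 20% to 50%.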

Compound 3, percent growth inhibition at one concentration: 7%
The estimate for compound 3 lay 28 percentage points above the measured number; the whole stated range lies above it.
By their numbers in this assay, from the lowest: compound 3; then compound 2; then compound 1.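

Within the data shown here, this is the first pair that differs in one place only, and in this assay it gives a number 26 percentage points lower from compound 2 to compound 3 (beyond the scatter) even though the two groups carry the same atoms. The change is only 2,3-dichlorophenyl in place of 2,6-dichlorophenyl, so at this position the arrangement of the two chlorines on the ring matters, not just their presence. Nothing among the data explains why the arrangement counts for so much.

On these data alone, it remains open what a plain phenyl group or a 2,6-dimethylphenyl group would give on the same carbon, and so whether chlorine itself is needed there. Also open, as far as these compounds go, is the role of the hydroxy group in (2,6-dichlorophenyl)(hydroxy)methyl, and compound 1 differs from compound 2 in too many places to settle either question.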